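The source may hold more compounds than are shown below. What is called first, only, known or untested is meant among the compounds shown, and "the series" means these compounds.

Going by the values given here, the two compounds measured so far share a common core and differ only in the groups hung on it. Compound 1 `CC(C)(C)c1cc(NC(=O)Nc2cc(F)cc(F)c2)n(-c2ccc(F)cc2)n1` in an assay on isolated protein for inhibition of STE20-like serine/threonine-protein kinase (Homo sapiens), read by thermal shift assay, tested at 10 uM (on this read-out lower numbers stand for weaker stabilisation of the target and higher numbers for stronger stabilisation of the target against heat), gives 2.7 degrees C. Compound 2 `CC(C)(C)c1cc(NC(=O)Nc2ccc(Cl)cc2)n(-c2ccc(C(F)(F)F)cc2)n1` in this assay gives 0.7 degrees C, the lower of the two numbers, with compound 1 standing higher by an amount beyond the usual scatter. Because compounds 1 and 2 differ from each other in two places at once, their gap cannot be assigned to any single change.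

Compound 3 `CC(C)(C)c1cc(NC(=O)Nc2ccc(Cl)cc2)n(-c2ccc(NS(C)(=O)=O)cc2)n1` has not yet been measured. It differs from compound 2 in one place: methanesulfonamido in place of trifluoromethyl on an aromatic carbon. Among the compounds with values here, no measured pair shows this particular change, so nothing observed gives its size or direction. Compound 2 in this assay stands at 0.7 degrees C, the lowest number seen, so the more probable outcome is a move upward or no clear move at all. The step from compound 2 to compound 3 is expected to be a number 0.80 degrees C higher from compound 2 to compound 3 (within the scatter), a modest gain that may not clearly exceed the scatter. Compound 3 in this assay is therefore estimated at 1.5 degrees C, within a range from 0 degrees C to 3.5 degrees C.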

Compound 3, shift of the target's melting temperature: 7.3 degrees C
For compound 3 the middle estimate is 5.8 degrees C below the measured one, outside the stated range (above it).
By their numbers in this assay, from the lowest: compound 2; then compound 1; then compound 3.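

The change from trifluoromethyl to methanesulfonamido, on an aromatic carbon para to a large group, gives a number 6.6 degrees C higher from compound 2 to compound 3 (beyond the scatter) in this assay. Going by these compounds alone, this is the first step here in which only one place changes, so this gap, unlike the one between the first two compounds, can be assigned to a single change and shows that the group at this position can by itself move the read-out by a large amount. The entering group brings one hydrogen-bond donor and two hydrogen-bond acceptors where the leaving group has none, but that count only describes the two groups, and no measurement available here accounts for the size of the step.

From the compounds shown here alone, it remains open which part of methanesulfonamido matters, and an amine, a carboxylic acid or the longer ethanesulfonamido chain at this position would help to separate the contribution of the nitrogen from that of the sulfonyl part. Within the data shown here, the step is also seen with only one set of remaining groups, so whether the same change would give a similar gain on compound 1 is unknown.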